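The source may hold more compounds than are shown below. What is called first, only, known or untested is meant among the compounds shown, and "the series" means these compounds.

Working notes on the series, read in an ADME assay on liver (Rattus norvegicus) for metabolic stability, read by LC-MS, using microsomes; a higher number here means faster removal of the compound, a lower number slower removal. Compound 1 (`Fc1ccc2c(CN3CCC(F)(F)[C@H](CCc4ccccc4)C3)c[nH]c2c1`) gives 2490 mL/min/kg, compound 2 (`Fc1ccc(CC[C@@H]2CN(Cc3c[nH]c4cc(Cl)ccc34)CCC2(F)F)cc1`) gives 582 mL/min/kg and compound 3 (`COc1ccc2c(CN3CCC(F)(F)[C@H](CCc4ccc(F)cc4)C3)c[nH]c2c1`) gives 957 mL/min/kg. Compound 3 thus lies within the scatter of compound 2, and its number is lower than that of compound 1 by more than the scatter.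

Compound 4 (`COc1ccc2c(CN3CCC(F)(F)[C@H](CCc4cccc(F)c4)C3)c[nH]c2c1`), still unmeasured, differs from compound 3 by 3-fluorophenyl in place of 4-fluorophenyl on a saturated chain carbon, two bonds along the chain from a saturated ring carbon. In words, this is 3-fluorophenyl in place of 4-fluorophenyl on a saturated chain carbon, two bonds along the chain from a saturated ring carbon.

Among the compounds with values here, the only measured step in one place is a 1.6-fold higher number from compound 2 to compound 3 (0.22 log units; within the scatter). That step is a different change, methoxy in place of chloro on an aromatic carbon, and it stays within the scatter. Within the data shown here, no measured pair tests the change from 4-fluorophenyl to 3-fluorophenyl. Compound 1 differs from compound 3 in more than one place, so it gives no clean comparison. With nothing measured pointing either way, no step beyond the scatter is expected in this assay, and the estimated step is a 1.0-fold lower number from compound 3 to compound 4 (0.00 log units; within the scatter). Compound 4 is estimated at 950 mL/min/kg, with an expected range of 480 mL/min/kg to 1900 mL/min/kg.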

Compound 4, clearance: 1060 mL/min/kg
Beside the measured number, compound 4's estimate is 1.1-fold (0.05 log units) below it, within the range that was stated.
By their numbers in this assay, from the lowest: compounds 2, 3 and 4 (each within the scatter of the next); then compound 1.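

Within the data shown here, the step of a 1.1-fold higher number from compound 3 to compound 4 (0.04 log units; within the scatter) in this assay is the first measured test of this position, a saturated chain carbon two bonds along the chain from a saturated ring carbon. With 3-fluorophenyl in place of 4-fluorophenyl, the two groups cannot be told apart in this assay, so for this pair, which has the same atoms joined differently, where the fluorine sits on the phenyl ring makes no difference beyond the scatter. The finding holds for this one pair only, with the methoxy-bearing core of compound 3 and compound 4, and no measured information on hand accounts for the result.

From the compounds shown here alone, whether a group of another kind at this position, such as a pyridyl ring, an amine or a carboxylic acid in place of the fluorophenyl, or a chain longer than the 2-(3-fluorophenyl)ethyl, would give a step beyond the scatter remains open. Also open, going by these compounds, is whether the same swap of 4-fluorophenyl for 3-fluorophenyl would stay within the scatter on the chloro-bearing core of compound 2.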